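A few compounds are considered here, and "the series" means these few. Any claim that something is new, unique, unknown or untested is made for them only; others in the source may bear on it.

Compound 1, `CNC(=O)CSc1nc2ccc(NC(=O)c3ccccc3OC)cc2s1`: 18500 nM
Compound 2, `COc1ccc(CNC(=O)CSc2nc3ccc(NC(=O)c4ccc(Cl)cc4)cc3s2)cc1`: 7400 nM
Compound 3, `CNC(=O)CSc1nc2ccc(NC(=O)CCl)cc2s1`: 1900 nM

Among the measured compounds shown here, in a functional assay on HepG2 cells (Homo sapiens) for cytotoxicity, read by MTT assay, with a stated time of 48 h (on this read-out higher numbers stand for weaker inhibition and lower numbers for stronger inhibition), compound 3 gives the lowest number of the three, and the only step measured between compounds that differ in one place, a 9.7-fold lower number from compound 1 to compound 3 (0.99 log units; beyond the scatter), leads to it. Compound 4, `COc1ccc(CNC(=O)CSc2nc3ccc(NC(=O)CCl)cc3s2)cc1`, differs from compound 3 by 4-methoxyphenyl in place of hydrogen on a saturated chain carbon bound to an amide-type nitrogen. For the measured compounds named here, no measured single-place step covers this change. Compounds 1 and 2 differ in the same way, but also in another place, so their pair only shows that compound 2 gives the lower number of the two. On that basis a small lowering, or none beyond the scatter, is expected, a 1.6-fold lower number from compound 3 to compound 4 (0.20 log units; within the scatter). Compound 4 is estimated at 1200 nM, within the range 500 nM to 3500 nM.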

Compound 4, half-maximal inhibitory concentration: 2000 nM
Estimate against measurement, compound 4: 1.7-fold (0.22 log units) below, and the stated range covers the measured number.
By their numbers in this assay, from the lowest: compounds 3 and 4 (each within the scatter of the next); then compound 2; then compound 1.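

Putting 4-methoxyphenyl in place of hydrogen on a saturated chain carbon bound to an amide-type nitrogen gives a 1.1-fold higher number from compound 3 to compound 4 (0.02 log units; within the scatter), so in this assay this added group makes no difference beyond the scatter while chloromethyl stays on the carbonyl carbon. With the 4-methoxybenzyl end kept, chloromethyl in place of 4-chlorophenyl gives a 3.7-fold lower number from compound 2 to compound 4 (0.57 log units; beyond the scatter), the same direction as a 9.7-fold lower number from compound 1 to compound 3 (0.99 log units; beyond the scatter), where 2-methoxyphenyl is replaced. No measurement here explains these steps.

On these data alone, whether a longer chain or an amine in this place would give a similar number remains open. So does whether 4-methoxyphenyl would also make no difference with 4-chlorophenyl on the carbonyl carbon.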